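Working notes: the aryl amide step to compound 3

The source may report more compounds than this note shows. Statements on the series, on what has been measured and on what is new or still open speak of the compounds shown alone.

For the measured compounds named here, in an ADME assay on HEp-2 cells (Homo sapiens) for cytotoxicity (a lower number here means that less compound is tolerated, a higher number that more compound is tolerated), compound 2 `Cc1cc(C)cc(NC(=O)[C@@H]2CCCN2S(=O)(=O)c2cccc3cccnc23)c1` gives 31300 nM as the only true number so far. Compound 1 `Cc1ccc(NC(=O)C(C)NS(=O)(=O)c2cccc3cccnc23)c(C)c1` stands at > 50000 nM as a limit of the assay and not a number. Going by the values given here, no step between measured compounds differing in one place is available, so this pair gives no size for a single change.

Compound 3 `COc1ccc(C)cc1NC(=O)[C@@H]1CCCN1S(=O)(=O)c1cccc2cccnc12` differs from compound 2 by 2-methoxy-5-methylphenyl in place of 3,5-dimethylphenyl on an amide-type nitrogen on an amide-type nitrogen. With compound 2 at 31300 nM as the only anchor, no shift beyond the usual scatter is expected in this assay for this swap. The expected move is a 1.1-fold higher number from compound 2 to compound 3 (0.05 log units; within the scatter) and counts as small. For compound 3 the estimated half-maximal cytotoxic concentration is 35000 nM with 15000 nM to 50000 nM as the expected range.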

Compound 3, half-maximal cytotoxic concentration: > 50000 nM
Compound 3 was reported as a limit; the forecaster's own chance of this, stated with the estimate: 35%; middle value at least 1.4-fold (0.15 log units) from the limit.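

In this assay, for the compounds shown here, 2-methoxy-5-methylphenyl in place of 3,5-dimethylphenyl on the amide-type nitrogen gives the first single-place step: an at least 1.5-fold higher number from compound 2 to compound 3 (0.20 log units; that floor lies within the scatter). Compound 3 gives > 50000 nM, which is a limit of the assay and not a number, so the step is a floor and not a measured size. The swap therefore shows only that this aryl change on the shared core does not give a lower number in this assay, and its full size stays unread because the read-out stops at that ceiling: the limit of > 50000 nM in this assay, at which 2 of the 3 values shown sit.

The compounds shown leave open how much of the step belongs to the methoxy group and how much to the change in methyl groups. Also open, from the compounds shown here alone, is whether a phenyl group carrying a carboxylic acid or an amine on the same nitrogen would give a true number in this assay.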